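Extending the acyl chain on a core with low inhibition in this assay

A few compounds are considered here, and "the series" means these few. Any claim that something is new, unique, unknown or untested is made for them only; others in the source may bear on it.

Measured so far:
compound 1 `CCCC(=O)C1=C(C)NC(=O)NC1c1cccs1`: 2%
compound 2 `CC(=O)C1=C(C)NC(=O)NC1c1ccsc1`: 1%

In an assay on membranes from HeLa cells for displacement of a labelled ligand from adenosine receptor A3 (Homo sapiens), read by scintillation counting, with a stated time of 180 min, tested at 1 uM (on this read-out lower numbers stand for less inhibition and higher numbers for more inhibition at the one concentration tested (going by the name of the read-out)), compound 1 gives 2% and compound 2 gives 1%; the two numbers lie within the scatter of each other, so neither stands apart, and both point to very little inhibition. Compound 3 `CCCC(=O)C1=C(C)NC(=O)NC1c1ccsc1` is the next compound; it differs from compound 2 by ethyl in place of hydrogen on a saturated chain carbon bound to a carbonyl carbon. Since compound 2 gives 1%, compound 3 is expected to stay at a similarly low level, with a step of a number 2 percentage points higher from compound 2 to compound 3 (within the scatter) that is not expected to go beyond the scatter. The estimate for compound 3 is 3%, in a range from -6% to 12%.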

Compound 3, a percentage reported as inhibition, at one concentration (the size of the read-out at that concentration, not a potency): 1%
For compound 3 the middle estimate is 2 percentage points above the measured one, within the range that was stated.
By their numbers in this assay, from the lowest: compounds 2, 3 and 1 (each within the scatter of the next).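

In this assay ethyl in place of hydrogen on a saturated chain carbon bound to a carbonyl carbon gives no change at the digits printed from compound 2 to compound 3 (within the scatter) and thiophen-3-yl in place of thiophen-2-yl on a saturated ring carbon gives a number 1 percentage points lower from compound 1 to compound 3 (within the scatter) so neither change takes the number beyond the usual scatter. The longer acyl chain therefore leaves this core at the same low level with either thiophene attachment. No separate measurement bears on this result.

The compounds shown leave open whether a much longer chain, an amine or a carboxylic acid on this chain would give clearer inhibition. They also leave open whether a phenyl ring in place of the thiophene would do so.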